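This account rests on a few compounds, and the source may have more. Where it says the series, first, only, none or still open, it means among the compounds named here.

Compound 1 `CC(C)=CCC/C(C)=C\CCC(C)=CCNCCN`: 32300 nM
Compound 2 `CC(C)=CCC/C(C)=C\CCC(C)=CCNCCCCCN`: 38400 nM

Both numbers come from a toxicity assay on CHO cells (Cricetulus griseus) for cytotoxicity, read by WST assay, with a stated time of 24 h; on this read-out higher numbers stand for weaker inhibition and lower numbers for stronger inhibition. Compound 2 has only compound 1 to be compared with, and the two cannot be told apart: the step is a 1.2-fold higher number from compound 1 to compound 2 (0.08 log units; within the scatter). The next structure, compound 3 `CC(C)=CCC/C(C)=C\CCC(C)=CCNCCCNCCCN`, alters the amine tail of compound 2: (3-aminopropyl)amino in place of 2-aminoethyl on a saturated chain carbon, three bonds along the chain from an amine nitrogen.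

Among the compounds with values here, only one measured step bears on this change. It replaced amino with 3-aminopropyl on the same kind of chain and gave a 1.2-fold higher number from compound 1 to compound 2 (0.08 log units; within the scatter). That is a small move, but it is a different change from the one at hand. Within the data shown here, no measured pair tests what happens when (3-aminopropyl)amino enters in place of 2-aminoethyl, so this evidence is thin. On that basis, no step beyond the scatter is expected in this assay, and no direction can be favoured with confidence. The expected step is a 1.3-fold lower number from compound 2 to compound 3 (0.11 log units; within the scatter). The estimate for compound 3 is 30000 nM, with an expected range of 12000 nM to 65000 nM.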

Compound 3, half-maximal inhibitory concentration: 30200 nM
Compound 3: the middle estimate sits 1.0-fold (0.00 log units) below what was measured; the range from low to high includes it.
By their numbers in this assay, from the lowest: compounds 3, 1 and 2 (each within the scatter of the next).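

Within the data shown here, until now the tail had only varied in length with a single amine nitrogen in it, so compound 3 is the first test of a group that brings in a further one. In this assay, putting (3-aminopropyl)amino in place of 2-aminoethyl gives a 1.3-fold lower number from compound 2 to compound 3 (0.10 log units; within the scatter), and the comparison with the shortest tail gives a 1.1-fold lower number from compound 1 to compound 3 (0.03 log units; within the scatter), so at this position neither the longer chain nor the entering group, with its 2 nitrogen atoms against 1 in the group it replaces, moves the number beyond the usual spread of repeated measurements. Nothing available here accounts for how closely the three numbers lie.

All three compounds end in a plain amine on an open chain, so a tail ending in a hydroxyl group or a carboxylic acid, or one closed into a piperazine ring, remains an open question. Also open, as far as these compounds go, is whether a still longer chain carrying more amine nitrogens would stay within that spread or finally separate from these three compounds in this assay.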